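Moving the chlorine from meta to ortho on a pyridine series

The compounds below may be only part of what the source reports. "The series", "measured", "known", "first", "only" and "open" are said of these compounds alone.

The series rests on a shared core carrying a 3-hydroxyphenyl group. Compound 1 `Oc1cccc(-c2cc(-c3ccncc3)nc(-c3cccc(Cl)c3)c2)c1` and compound 2 `Oc1cccc(-c2cc(-c3cccc(Cl)c3)nc(-c3ccccn3)c2)c1` were both tested in an ADME assay on HEK293 cells (Homo sapiens) for cytotoxicity, read by CCK-8 assay and cell counting, with a stated time of 2 days (on this read-out higher numbers stand for weaker inhibition and lower numbers for stronger inhibition), but for neither of them was a result reported: compound 1 stands at "not determined" (no result reported) and compound 2 stands at "not determined" (no result reported). For the measured compounds named here, compound 3 `Oc1cccc(-c2cc(-c3cccc(Cl)c3)nc(-c3ccco3)c2)c1` is the only member with a number: in this assay compound 3 gives 2530 nM. With no second value to compare against, compound 3 neither leads nor trails anything; it simply sets the single reference point of the set.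

Compound 4 `Oc1cccc(-c2cc(-c3ccco3)nc(-c3ccccc3Cl)c2)c1` is built from the same atoms as compound 3, joined differently: 2-chlorophenyl in place of 3-chlorophenyl on an aromatic carbon. Going by the values given here, no pair of measured compounds shows what such a rearrangement does in this assay, so the expectation for compound 4 rests on compound 3 alone, whose value of 2530 nM is taken as the anchor. The step of a 1.0-fold lower number from compound 3 to compound 4 (0.01 log units; within the scatter) is expected to stay within the usual scatter, in no firm direction. Compound 4 is therefore estimated at 2500 nM in this assay, with a range from 900 nM to 7000 nM.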

Compound 4, half-maximal inhibitory concentration: 1860 nM
Beside the measured number, compound 4's estimate is 1.3-fold (0.13 log units) above it; the range from low to high includes it.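

In this assay, for the compounds shown here, compounds 3 and 4 form the first pair that differs in one place, and the step is a 1.4-fold lower number from compound 3 to compound 4 (0.13 log units; within the scatter) with 2-chlorophenyl in place of 3-chlorophenyl on the aromatic carbon next to the ring nitrogen. Going by these compounds alone, for this pair, then, moving the chlorine around the phenyl ring leaves the two values within the scatter of each other, which the single number available before could not show, though one pair sets no pattern for the series. Nothing at hand offers any measured explanation for this result.

From the compounds shown here alone, whether an amine or a carboxylic acid in place of the chlorine would carry the number beyond the scatter stays open. So does the effect of replacing the furan-2-yl group with a longer chain.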